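This account rests on a few compounds, and the source may have more. Where it says the series, first, only, none or still open, it means among the compounds named here.

Compound 1, `Cc1ccnc(/C(N)=N/NC(=S)N2CCOCC2)c1`: 5.07%. Compound 2, `N/C(=N\NC(=S)N1CCCC1)c1ccccn1`: 49.8%.

In a functional assay on MCF7 cells (Homo sapiens) for cytotoxicity, read by MTT assay, with a stated time of 72 h, tested at 3 uM (a higher number here means more inhibition of growth at the concentration tested, a lower number less inhibition of growth), compound 2 gives 49.8%, the higher of the two numbers here, while compound 1 gives 5.07% in this assay, a gap beyond the scatter. Going by the values given here, compound 1 and compound 2 differ in more than one place, so no single step between them is known. Compound 3, `Cc1ccnc(/C(N)=N/NC(=S)N2CCCC2)c1`, is compound 2 changed by methyl in place of hydrogen on an aromatic carbon. Compound 1 carries the same methyl and sits low, at 5.07%, yet it also differs from compound 2 in the ring attached to the thiourea, so how much of that gap belongs to the methyl cannot be told. For compound 3 the expected step is a number 19.8 percentage points lower from compound 2 to compound 3 (beyond the scatter), a moderate drop that may or may not exceed the scatter. The estimate for compound 3 in this assay is 30%, within the range 5% to 55%.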

Compound 3, percent growth inhibition at one concentration: 57.7%
Estimate against measurement, compound 3: 27.7 percentage points below; measured number outside the range, above it.
By their numbers in this assay, from the lowest: compound 1; then compounds 2 and 3 (each within the scatter of the next).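

In this assay, the step for methyl in place of hydrogen on the aromatic carbon opposite the ring nitrogen is a number 7.9 percentage points higher from compound 2 to compound 3 (within the scatter), so at this position the methyl leaves no change that can be told from the scatter. With that methyl present in both compounds, pyrrolidin-1-yl in place of morpholin-4-yl on the thiocarbonyl carbon gives a number 52.6 percentage points higher from compound 1 to compound 3 (beyond the scatter), which ties the low number of compound 1 to its morpholin-4-yl ring and not to the methyl. Nothing measured here gives a reason for either step.

On these data alone, how an ethyl, a methoxy or an amine at this same aromatic carbon would compare with the methyl stays open. Also open, as far as these compounds go, is where a piperidin-1-yl ring or an open-chain diethylamino group on the thiocarbonyl carbon would fall relative to the two rings seen so far.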